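Removing the Sulfonyl from the Azetidine of Compound 1

A few compounds are considered here, and "the series" means these few. Any claim that something is new, unique, unknown or untested is made for them only; others in the source may bear on it.

Compound 1 `CS(=O)(=O)CCCn1c(Cn2c(=O)n(C3CN(S(C)(=O)=O)C3)c3ccncc32)cc2cc(Cl)ccc21` was tested in an ADME assay on HeLa cells (Homo sapiens) for cytotoxicity, read by ATP content, with a stated time of 3 days; on this read-out lower numbers stand for higher toxicity in this test and higher numbers for lower toxicity in this test. In this assay compound 1 gives > 50000 nM, which is a limit of the assay rather than a number. Two related compounds share its core. Compound 2 `O=C(O)CCCn1c(Cn2c(=O)n(C3CC3)c3ccncc32)cc2cc(Cl)ccc21` gives > 50000 nM in this assay, likewise a limit. Compound 3 `CC(C)(O)CCCn1c(Cn2c(=O)n(C3CC3)c3ccncc32)cc2cc(Cl)ccc21` gives > 50000 nM in this assay, again a limit. For the measured compounds named here, the only step between measured compounds, a step that the two limits leave unreadable from compound 2 to compound 3, lies on the chain and not on the ring that is changed here. Compound 4 `CS(=O)(=O)CCCn1c(Cn2c(=O)n(C3CNC3)c3ccncc32)cc2cc(Cl)ccc21` differs from compound 1 by hydrogen in place of methylsulfonyl on an amine nitrogen in a ring. Going by the values given here, no measured step touches this position, and all the numbers in hand sit at the limit of > 50000 nM in this assay, at which 3 of the 3 values shown sit, so no direction and no size beyond the scatter can be read for the change. Compound 1 stands at the limit with both of its neighbours. Compound 4 is therefore estimated to give 60000 nM in this assay, with a range from 25000 nM to 150000 nM. The step that the limit leaves unreadable from compound 1 to compound 4 is expected to be none beyond the scatter.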

Compound 4, half-maximal cytotoxic concentration: > 50000 nM
Compound 4 gave a limit, no number (the forecaster's own chance of this, stated with the estimate: 85%); the middle value lies beyond the limit too.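

In this assay, compound 1 and compound 4 each give a limit rather than a number, and no step can be read between them: the limit of > 50000 nM in this assay, at which 4 of the 4 values shown sit.

The compounds shown leave open whether hydrogen in place of methylsulfonyl on the amine nitrogen changes the half-maximal cytotoxic concentration at all, and where that concentration lies for any of them.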